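Thiophene-to-furan exchange on a nucleoside core

The compounds below may be only part of what the source reports. "The series", "measured", "known", "first", "only" and "open" are said of these compounds alone.

Measured compounds in a functional assay on HCT-116 cells (Homo sapiens), read by MTT assay, with a stated time of 72 h; a lower number here means a stronger inhibitor, a higher number a weaker inhibitor:
- compound 1 `Cc1nc(N)c2c(-c3cccs3)cn([C@@H]3O[C@H](CO)[C@@H](O)[C@H]3O)c2n1`: a limit of the assay, > 20000 nM
- compound 2 `Nc1nc2c(c(-c3cccs3)cn2[C@@H]2O[C@H](CO)[C@@H](O)[C@H]2O)c(=O)[nH]1`: 19800 nM
- compound 3 `Cc1nc(N)c2c(-c3ccoc3)cn([C@@H]3O[C@H](CO)[C@@H](O)[C@H]3O)c2n1`: a limit of the assay, > 20000 nM

For the measured compounds named here, compound 2 carries the only number in this assay. The difference between the core of compound 1 and the core of compound 2 is not broken down here. From compound 1 to compound 3 the change is furan-3-yl in place of thiophen-2-yl on an aromatic carbon; the step that the two limits leave unreadable from compound 1 to compound 3 cannot be sized because of the limit of > 20000 nM in this assay, at which 2 of the 3 values shown sit.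

Compound 4 `Nc1nc2c(c(-c3ccoc3)cn2[C@@H]2O[C@H](CO)[C@@H](O)[C@H]2O)c(=O)[nH]1` is not yet measured. It differs from compound 2 by furan-3-yl in place of thiophen-2-yl on an aromatic carbon, the same change as from compound 1 to compound 3, at the same place. With that earlier step unreadable, the expectation for compound 4 rests only on compound 2 at 19800 nM and is a step of a 1.3-fold higher number from compound 2 to compound 4 (0.10 log units; within the scatter). Compound 4 is therefore estimated at 25000 nM, between 12000 nM and 60000 nM, with a fair chance that this assay returns only a limit.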

Compound 4, half-maximal inhibitory concentration: 17600 nM
The estimate for compound 4 lay 1.4-fold (0.15 log units) above the measured number; low and high end bracket the measured number.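

Furan-3-yl in place of thiophen-2-yl gives a 1.1-fold lower number from compound 2 to compound 4 (0.05 log units; within the scatter) in this assay, so on this core the exchange moves the number no further than the scatter. The same exchange on the core of compound 1 cannot be read, as both values there are limits: the limit of > 20000 nM in this assay, at which 2 of the 4 values shown sit. The carrying of this change from one core to the other is therefore neither confirmed nor refuted, and the reading rests on a single pair.

Still open, as far as these compounds go, is whether a group other than these two aromatic rings, such as an amine or a longer alkyl chain, on the same aromatic carbon would give a lower number in this assay. Also open, from the compounds shown here alone, is whether any such group would bring the core of compound 1 to a readable number.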